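The source may hold more compounds than are shown below. What is called first, only, known or untested is meant among the compounds shown, and "the series" means these compounds.

Series in a functional assay on DU-145 cells (Homo sapiens) for cytotoxicity, read by MTT assay; a higher number here means a weaker inhibitor, a lower number a stronger inhibitor:
- compound 1 `CC(=O)OCCC(=O)O[C@H](CC=C(C)C)C1=CC(=O)c2c(O)ccc(O)c2C1=O`: 15700 nM
- compound 2 `CCCCC(O)CC(=O)O[C@H](CC=C(C)C)C1=CC(=O)c2c(O)ccc(O)c2C1=O`: 45300 nM
- compound 3 `CC[C@@](C)(O)CC(=O)O[C@H](CC=C(C)C)C1=CC(=O)c2c(O)ccc(O)c2C1=O`: 12700 nM
- compound 4 `CC(C)=CC[C@@H](OC(=O)CC(C)(O)c1ccccc1)C1=CC(=O)c2c(O)ccc(O)c2C1=O`: not yet measured

Compound 3 cannot be separated from compound 1, with a 1.2-fold lower number from compound 1 to compound 3 (0.09 log units; within the scatter). It does stand apart from compound 2, with a 3.6-fold lower number from compound 2 to compound 3 (0.55 log units; beyond the scatter).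

The next change is 1-hydroxy-1-phenylethyl in place of 1-hydroxy-1-methylpropyl on a saturated chain carbon bound to a carbonyl carbon. In words, this is 1-hydroxy-1-phenylethyl in place of 1-hydroxy-1-methylpropyl on a saturated chain carbon bound to a carbonyl carbon. Within the data shown here, no measured compound carries an aromatic ring at this place, so no measured step transfers directly. The closest evidence is the three steps at the same place. Besides the two above, there is a 2.9-fold higher number from compound 1 to compound 2 (0.46 log units; beyond the scatter). Those beyond the scatter are modest, and the data give no direction for the entering group.

In this assay, no step beyond the scatter is therefore expected, although a modest step either way would not be surprising. The expected change is a 1.2-fold lower number from compound 3 to compound 4 (0.06 log units; within the scatter). The estimate for compound 4 is 11000 nM, with an expected range of 4500 nM to 28000 nM.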

Compound 4, half-maximal inhibitory concentration: > 100000 nM
Compound 4: only a limit was reported; the forecaster's own chance of this, stated with the estimate: 5%; at least 9.0-fold (0.95 log units) between middle value and limit.
By their numbers in this assay, from the lowest: compounds 3 and 1 (each within the scatter of the next); then compound 2. At a limit, above all of these: compound 4.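

In this assay compound 4 stands at a limit of the assay and not at a number: the limit of > 100000 nM in this assay, at which 1 of the 4 values shown sits. Read against that limit, the 1-hydroxy-1-phenylethyl group gives an at least 7.8-fold higher number from compound 3 to compound 4 (0.89 log units; beyond the scatter), an at least 6.3-fold higher number from compound 1 to compound 4 (0.80 log units; beyond the scatter) and an at least 2.2-fold higher number from compound 2 to compound 4 (0.34 log units; beyond the scatter), whereas the steps among the three open-chain groups were modest or within the scatter, so a group on a saturated chain carbon bound to a carbonyl carbon is not interchangeable here, and the one compound with a ring at this place is the one that reaches the limit. Between compound 3 and compound 4 the counts of hydrogen-bond donors and acceptors and the net charge stay the same, so the change lies in the six-membered aromatic ring of carbon only and the added heavy atoms.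

One compound cannot show whether the loss goes with the aromatic ring or with the size of the entering group, and a cyclohexyl group at the same place would separate the two. From the compounds shown here alone, how far the number truly lies past the limit also stays open, as does the reading for a pyridyl ring, or for an amine or a carboxylic acid on the same chain.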